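The source may hold more compounds than are shown below. What is called first, only, known or untested is meant among the compounds shown, and "the series" means these compounds.

Compound 1, `CN(C)C(=O)CN1CCC(c2cc3c(-c4ccc(=O)n(C5CCC5)c4)ccnc3[nH]2)CC1`, in an ADME assay on cells (Hepatocyte, Homo sapiens) for metabolic stability (on this read-out lower numbers stand for slow clearance and higher numbers for fast clearance), reports a value that is a limit of the assay, not a number: < 1 uL/min. Compound 2, `CC(C)n1nc(-c2ccnc3[nH]c(C4CCN(CC(=O)N(C)C)CC4)cc23)ccc1=O`, in this assay gives 2 uL/min. Compound 3, `CC(C)n1cc(-c2ccnc3[nH]c(C4CCN(CC(=O)N5CCCC5)CC4)cc23)ccc1=O`, gives 3.5 uL/min.

Going by the values given here, of the three compounds, only two give full numbers, and compound 3 is one of them. Its number and that of compound 2 lie within the usual scatter of each other, so the two cannot be told apart; compound 1 stands apart only in that it reports a limit (the limit of < 1 uL/min in this assay, at which 1 of the 3 values shown sits).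

Compound 4, `CC(C)n1cc(-c2ccnc3[nH]c(C4CCN(CC(=O)N(C)C)CC4)cc23)ccc1=O`, is the next compound to be tested. It differs from compound 3 in one place: dimethylamino in place of pyrrolidin-1-yl on a carbonyl carbon. Compound 3 carries the (pyrrolidin-1-yl)carbonyl group, compound 4 the dimethylcarbamoyl group on the same saturated chain carbon. Among the compounds with values here, no pair of measured compounds differs in just this way, so the size of the step has to be judged from what the numbers show. Compound 2 also carries the dimethylcarbamoyl group, and its number sits close to that of compound 3.

The step from compound 3 to compound 4 is expected to be small, a 1.4-fold lower number from compound 3 to compound 4 (0.15 log units; within the scatter), no more than the scatter. Compound 4 is therefore estimated at 2.5 uL/min, within a range from 1 uL/min to 6 uL/min.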

Compound 4, intrinsic clearance in a liver preparation (reported as CLH), per the amount of preparation that the assay uses: < 1 uL/min
Compound 4 was reported as a limit; the forecaster's own chance of this, stated with the estimate: 15%; middle value at least 2.5-fold (0.39 log units) away from the limit.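

In this assay compound 4 reports a limit of the assay, not a number: < 1 uL/min. Putting dimethylamino in place of pyrrolidin-1-yl on a carbonyl carbon gives an at least 3.5-fold lower number from compound 3 to compound 4 (0.54 log units; beyond the scatter), the first sign that this position, where the carbonyl carbon's other neighbour is a saturated chain carbon, can shift the read-out by more than the usual scatter, even though the change is confined to a small group. Replacing the group on an aromatic carbon, with one six-membered aromatic ring with 2 hetero atoms giving way to one with 1 hetero atom, gives an at least 2.0-fold lower number from compound 2 to compound 4 (0.30 log units; that floor lies within the scatter), so this second change may be small or larger, and the step between compound 1 and compound 4 cannot be read at all: the limit of < 1 uL/min in this assay, at which 2 of the 4 values shown sit.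

The limit leaves the full size of both readable steps unknown, and a single pair cannot show whether the first step would hold with another group on the aromatic nitrogen. On these data alone, it also remains open how a morpholin-4-yl, azetidin-1-yl or methylamino group would read on the same carbonyl carbon.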